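A few compounds are considered here, and "the series" means these few. Any claim that something is new, unique, unknown or untested is made for them only; others in the source may bear on it.

Going by the values given here, in a functional assay on CHO cells for agonist activity at Free fatty acid receptor 1 (Homo sapiens), read by FLIPR and calcium flux, tested at 100 nM (on this read-out lower numbers stand for a weaker effect and higher numbers for a stronger effect at the one concentration tested), two compounds have numbers so far. Compound 1 `O=C(O)CC1COc2cc(OCc3nc(-c4ccccc4)cs3)ccc21` carries a plain phenyl group on its five-membered aromatic ring with one nitrogen and one sulfur, and in this assay compound 1 gives 0.16%. Compound 2 `Cc1nc(-c2cc3ccccc3o2)sc1COc1ccc2c(c1)OCC2CC(=O)O` carries a 1-benzofuran-2-yl group there instead, and in this assay compound 2 gives 14.8%, the higher of the two numbers, with compound 1 lying a gap beyond the usual scatter beneath it. Compound 3 `Cc1nc(-c2ccc(Cl)cc2)sc1COc1ccc2c(c1)OCC2CC(=O)O` has not been measured; it differs from compound 2 in one place: 4-chlorophenyl in place of 1-benzofuran-2-yl on an aromatic carbon. Among the compounds with values here, no measured pair matches this exchange, so the expectation rests only on the two values shown. Because compound 1 with a plain phenyl group gives 0.16%, a drop is expected when the 1-benzofuran-2-yl group leaves, though the chlorine may hold part of the activity. The expected step is a number 9.8 percentage points lower from compound 2 to compound 3 (within the scatter), downward. Compound 3 is estimated at 5%, within a range from 0% to 18%.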

Compound 3, a percentage reported as activity, at one concentration (the size of the read-out at that concentration, not a potency): 53.4%
Compound 3: middle estimate off by 48.4 percentage points, on the low side; measured number outside the range, above it.
By their numbers in this assay, from the lowest: compound 1; then compound 2; then compound 3.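

In this assay, exchanging 1-benzofuran-2-yl for 4-chlorophenyl gives a number 38.6 percentage points higher from compound 2 to compound 3 (beyond the scatter), so the group on this aromatic carbon has a large effect on the read-out at the one concentration tested. The fused five-membered ring with its oxygen is therefore not needed for activity here, and the single six-membered carbon ring with its chlorine, the smaller group by heavy atoms, gives the higher number. Nothing measured here explains this gain.

As far as these compounds go, the share of the chlorine stays open: compound 1 has a plain phenyl group but also lacks the methyl group of compound 3, so the two differ in more than one place. From the compounds shown here alone, how a 4-methoxyphenyl or a 4-trifluoromethylphenyl group would read at this position also remains open.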